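From compound 3 to compound 4: an acetyl exchange

The source may hold more compounds than are shown below. What is called first, only, known or untested is meant among the compounds shown, and "the series" means these compounds.

Measured so far in a physicochemical assay for metabolic stability, at pH 8, in the presence of a further agent that is not named here; on this read-out higher numbers stand for a longer-lived compound and lower numbers for a shorter-lived compound
Compound 1 (`Cc1cn([C@H]2CO[C@@H](COC(=O)C3CCCCC3)O2)c(=O)[nH]c1=O`) gives 0.322 h
Compound 2 (`CCCCCCCC(=O)OC[C@@H]1OC[C@H](n2cc(C)c(=O)[nH]c2=O)O1`) gives 0.483 h
Compound 3 (`Cc1cn([C@H]2CO[C@@H](COCOC(=O)C(C)(C)C)O2)c(=O)[nH]c1=O`) gives 0.293 h

Compound 3 stands within the scatter of both compound 1 and compound 2, so the three values cannot be ranked. Compound 4 (`CC(=O)OC[C@@H]1OC[C@H](n2cc(C)c(=O)[nH]c2=O)O1`) follows from compound 3 through acetyl in place of (((tert-butyl)carbonyl)oxy)methyl on an oxygen on a saturated carbon and carries acetyl in place of (((tert-butyl)carbonyl)oxy)methyl on an oxygen on a saturated carbon. Going by the values given here, two measured steps bear on this exchange, a 1.5-fold higher number from compound 1 to compound 2 (0.18 log units; within the scatter) and a 1.1-fold lower number from compound 1 to compound 3 (0.04 log units; within the scatter) and neither goes beyond the scatter. Among the compounds with values here, no measured compound carries acetyl, so the expectation remains loose. No change beyond the scatter is expected in this assay and the expected step is a 1.2-fold higher number from compound 3 to compound 4 (0.08 log units; within the scatter) in size. Compound 4 is estimated at 0.35 h (expected range 0.15 h to 0.8 h).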

Compound 4, half-life: 0.272 h
The estimate for compound 4 lay 1.3-fold (0.11 log units) above the measured number, and the stated range covers the measured number.
By their numbers in this assay, from the lowest: compounds 4, 3, 1 and 2 (each within the scatter of the next).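

In this assay acetyl on this oxygen gives a 1.1-fold lower number from compound 3 to compound 4 (0.03 log units; within the scatter) and a 1.8-fold lower number from compound 2 to compound 4 (0.25 log units; within the scatter) and a 1.2-fold lower number from compound 1 to compound 4 (0.07 log units; within the scatter) and so stays within the scatter of all three other groups at this place. Even with 3 heavy atoms entering where 8 leave, the read-out does not move beyond the scatter, and the four compounds cannot be ranked. Nothing shown offers an explanation for this result. As far as these compounds go, whether a benzoyl group or an amino acid ester on this oxygen would reach beyond the scatter stays open.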